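This account rests on a few compounds, and the source may have more. Where it says the series, first, only, none or still open, it means among the compounds named here.

Measured so far:
compound 1 `O=C(C1CCC(F)(F)CC1)N1CC(c2nc(-c3cccc(Cl)c3)no2)C1` — 180 nM
compound 2 `Cc1cccc(-c2noc(C3CN(C(=O)C4CCC(C(F)(F)F)CC4)C3)n2)c1` — 1000 nM

In an assay on HEK293 cells for positive allosteric modulation of metabotropic glutamate receptor 5 (Homo sapiens), read by FLIPR (a higher number here means that more compound is needed for the effect, a lower number that less compound is needed), compound 1 gives 180 nM, the lower of the two numbers; compound 2 gives 1000 nM, a gap that lies beyond the usual scatter. These two compounds differ in more than one place, so their values alone say nothing about any single change.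

Compound 3 `O=C(N1CCC(F)CC1)N1CC(c2nc(-c3cccc(Cl)c3)no2)C1` is not yet measured. It differs from compound 1 in one place: 4-fluoropiperidin-1-yl in place of 4,4-difluorocyclohexyl on a carbonyl carbon. The 4-fluoropiperidin-1-yl group on the carbonyl carbon carries one fluorine where 4,4-difluorocyclohexyl carried two.

Without a measured step of this kind, a modest move toward a higher number is expected, roughly at the edge of the scatter, as a 2.2-fold higher number from compound 1 to compound 3 (0.35 log units; beyond the scatter). Compound 3 is expected to give about 400 nM in this assay, with a likely range from 130 nM to 1200 nM.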

Compound 3, half-maximal effective concentration: 990 nM
Estimate against measurement, compound 3: 2.5-fold (0.39 log units) below; the range from low to high includes it.
By their numbers in this assay, from the lowest: compound 1; then compounds 3 and 2 (each within the scatter of the next).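

In this assay, for the compounds shown here, the step to 4-fluoropiperidin-1-yl in place of 4,4-difluorocyclohexyl on a carbonyl carbon is a 5.5-fold higher number from compound 1 to compound 3 (0.74 log units; beyond the scatter) and gives the first reading of a single change at this position. The swap replaces a ring of carbon only with a ring holding one hetero atom and also removes one fluorine, so this single step cannot separate those two differences. Nothing measured here explains the step.

Open, as far as these compounds go, is how a plain cyclohexyl or a plain piperidin-1-yl on the same carbonyl carbon compares with compound 1. A morpholine there remains an open question too.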